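The compounds below may be only part of what the source reports. "The series", "measured", "known", "first", "only" and "open" are said of these compounds alone.

In a functional assay on HeLa cells (Homo sapiens) for inhibition, read by MTT assay, with a stated time of 4 days (a lower number here means a stronger inhibitor, a higher number a weaker inhibitor), compound 1 (`COc1cc(NC(C)CCCNC(=O)NNC(=O)Nc2ccc(Cl)c(C(F)(F)F)c2)c2ncccc2c1`) gives 17000 nM. For the measured compounds named here, this is the lower of the two numbers so far, a real gap from compound 2 (`CCOC(=O)N(C)C(c1ccccc1)c1ccccc1`), which gives 80000 nM. Compound 3 (`COc1cc(NC(C)CCCNC(=O)NNC(=O)N(CCO)CCO)c2ncccc2c1`) keeps the rest of compound 1 but has bis(2-hydroxyethyl)amino in place of (4-chloro-3-(trifluoromethyl)phenyl)amino on a carbonyl carbon. Going by the values given here, no measured pair shows this kind of change, so the expectation is uncertain: a modest step towards weaker inhibition, probably beyond the scatter. The expected step is a 2.9-fold higher number from compound 1 to compound 3 (0.47 log units; beyond the scatter). Compound 3 is estimated at 50000 nM, with an expected range of 18000 nM to 130000 nM.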

Compound 3, half-maximal inhibitory concentration: > 250000 nM
Compound 3: a limit, no number; the forecaster's own chance of this, stated with the estimate: 35%; middle value at least 5.0-fold (0.69 log units) away from the limit.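

For the compounds shown here, this is the first pair to show that the group on this carbonyl carbon strongly affects the result: in this assay, replacing (4-chloro-3-(trifluoromethyl)phenyl)amino with bis(2-hydroxyethyl)amino gives an at least 14-fold higher number from compound 1 to compound 3 (1.16 log units; beyond the scatter). The value for compound 3 is a limit of the assay, not a number: the limit of > 250000 nM in this assay, at which 1 of the 3 values shown sits.

The compounds shown cannot tell whether the aromatic ring, its chlorine and trifluoromethyl substituents, or the entering hydroxyethyl chains account for this loss. A plain phenylamino group at this carbonyl carbon would help separate these possibilities.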